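Swapping the aryl on the core: an estimate of clearance

The source may hold more compounds than are shown below. What is called first, only, known or untested is meant among the compounds shown, and "the series" means these compounds.

Compound 1: `O=S(=O)(c1ccc(F)c(F)c1)c1cnc2cc(F)ccc2c1-c1cccc(Cl)c1` — 0.38 mL/min
Compound 2: `COc1ccc(S(=O)(=O)c2cnc3cc(F)ccc3c2-c2cccc(Cl)c2)cc1Cl` — 1.19 mL/min

Of the compounds shown here, two sharing one core have been measured in an ADME assay on microsomes from liver (Homo sapiens) for metabolic stability, tested at 2.5 uM; on this read-out lower numbers stand for slow clearance and higher numbers for fast clearance. Compound 1 gives 0.38 mL/min, the lowest of the two numbers shown, and its nearest neighbour is compound 2 at 1.19 mL/min. Among the measured compounds shown here, the one measured step, a 3.1-fold higher number from compound 1 to compound 2 (0.50 log units; beyond the scatter), comes from 3-chloro-4-methoxyphenyl in place of 3,4-difluorophenyl on a sulfonyl sulfur.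

Compound 3, `O=S(=O)(c1ccc(F)c(F)c1)c1cnc2cc(F)ccc2c1-c1ccccc1F`, differs from compound 1 at another site: 2-fluorophenyl in place of 3-chlorophenyl on an aromatic carbon. The sulfonyl side is left as it is in compound 1. For the measured compounds named here, no measured step touches the aryl on the aromatic carbon of the core, so the step from compound 1 to compound 2 does not speak to this change, and nothing in the data points one way or the other.

The expectation is therefore a step of a 1.1-fold higher number from compound 1 to compound 3 (0.02 log units; within the scatter), that is, none beyond the scatter. Compound 3 is estimated at 0.4 mL/min in this assay, within a range from 0.15 mL/min to 1.05 mL/min.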

Compound 3, intrinsic clearance in a liver preparation (reported as CLH), per the amount of preparation that the assay uses: 0.79 mL/min
Compound 3: the middle estimate sits 2.0-fold (0.30 log units) below what was measured; the measured number falls inside the stated range.
By their numbers in this assay, from the lowest: compound 1; then compounds 3 and 2 (each within the scatter of the next).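

In this assay the aryl on the aromatic carbon of the core proves able to move the number: a 2.1-fold higher number from compound 1 to compound 3 (0.32 log units; beyond the scatter) comes with 2-fluorophenyl in place of 3-chlorophenyl, a modest step but one beyond the scatter. Among the compounds shown here, the read-out therefore responds at this position as well as on the sulfonyl sulfur, where a 3.1-fold higher number from compound 1 to compound 2 (0.50 log units; beyond the scatter) had been the only measured step, and both changes made to compound 1 lead to a higher number. This one swap alters both the halogen and where it sits on the phenyl, the compounds shown do not separate the two, and no measurement is at hand that bears on what lies behind the step.

As far as these compounds go, what stays open is where a 2-chlorophenyl, a 3-fluorophenyl or a plain phenyl would fall at this position, which would pull the halogen apart from its place, and whether a pyridyl or an aminophenyl there would shift the number further. Open too, from the compounds shown here alone, is whether the two steps add up when 3-chloro-4-methoxyphenyl on the sulfonyl sulfur meets 2-fluorophenyl on the aromatic carbon.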